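Halogen variation on the aryl group at the ring nitrogen

The source may hold more compounds than are shown below. What is called first, only, known or untested is meant among the compounds shown, and "the series" means these compounds.

Measured compounds:
compound 1 `O=C(Nc1ccc(Oc2ncnc3ccsc23)c(F)c1)c1nn(-c2ccc(F)cc2)ccc1=O` — 9160 nM
compound 2 `O=C(Nc1ccc(Oc2ncnc3ccsc23)c(F)c1)c1nn(-c2ccc(F)c(Cl)c2)ccc1=O` — 10600 nM

In a functional assay on HepG2 cells (Homo sapiens) for cytotoxicity, read by MTT assay, with a stated time of 72 h (on this read-out higher numbers stand for weaker inhibition and lower numbers for stronger inhibition), compound 1 gives 9160 nM, and compound 2 gives 10600 nM. Compound 2 has the highest of the two numbers, with compound 1 nearest; the step of a 1.2-fold higher number from compound 1 to compound 2 (0.06 log units; within the scatter) lies within the scatter, so the two compounds cannot be told apart on this read-out.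

Compound 3 `O=C(Nc1ccc(Oc2ncnc3ccsc23)c(F)c1)c1nn(-c2ccc(Br)cc2)ccc1=O` differs from compound 2 by 4-bromophenyl in place of 3-chloro-4-fluorophenyl on an aromatic nitrogen. For the measured compounds named here, the only measured step that touches this aryl group is a 1.2-fold higher number from compound 1 to compound 2 (0.06 log units; within the scatter), which is within the scatter. With one halogen exchanged for another at the same ring and the extra chlorine removed, no step beyond the scatter is expected in this assay, so the expected step is a 1.1-fold lower number from compound 2 to compound 3 (0.05 log units; within the scatter). Compound 3 is therefore estimated at 9500 nM, with a range from 4500 nM to 20000 nM.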

Compound 3, half-maximal inhibitory concentration: 10700 nM
For compound 3 the middle estimate is 1.1-fold (0.05 log units) below the measured one, within the range that was stated.
By their numbers in this assay, from the lowest: compounds 1, 2 and 3 (each within the scatter of the next).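

In this assay, the exchange of the whole aryl group gives a 1.0-fold higher number from compound 2 to compound 3 (0.00 log units; within the scatter), and bromo in place of fluoro on an aromatic carbon gives a 1.2-fold higher number from compound 1 to compound 3 (0.07 log units; within the scatter). Compound 3 thus adds a halogen exchange to the earlier chloro addition, and neither change, nor the removal of chloro together with the exchange of fluoro for bromo, separates the compounds on this read-out. No measured property of these groups is available to bear on this result.

The compounds shown carry only halogens on this aryl group, so it stays open whether a non-halogen substituent such as an amine, a carboxylic acid or a methoxy group would give a step beyond the scatter. The same question stands for the unsubstituted phenyl group and for a longer alkyl chain in place of the aryl group on the ring nitrogen.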